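A few compounds are considered here, and "the series" means these few. Any claim that something is new, unique, unknown or untested is made for them only; others in the source may bear on it.

In an ADME assay on HEp-2 cells (Homo sapiens) for cytotoxicity (on this read-out lower numbers stand for higher toxicity in this test and higher numbers for lower toxicity in this test), three compounds with a shared core have been measured:

- compound 1 `CC(C)CCn1c(Cn2c(=O)n(C(C)C)c3ccccc32)nc2cc(CN)ccc21`: 3920 nM
- compound 2 `CNCc1ccc2c(c1)nc(Cn1c(=O)n(C(C)C)c3ccccc31)n2CCC(C)C`: 1480 nM
- compound 3 `CC(C)CCn1c(Cn2c(=O)n(C(C)C)c3ccccc32)nc2cc(Br)ccc21`: 18100 nM

Compound 3, at 18100 nM, has the highest number of the three, and its steps to the other two lie beyond the scatter. Compound 4 `CC(C)CCn1c(Cn2c(=O)n(C(C)C)c3ccccc32)nc2cc(-c3nn[nH]n3)ccc21` has not yet been measured. It differs from compound 3 as follows: 2H-tetrazol-5-yl in place of bromo on an aromatic carbon. In short, it has 2H-tetrazol-5-yl in place of bromo on an aromatic carbon.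

Going by the values given here, two measured steps concern this same carbon: a 4.6-fold higher number from compound 1 to compound 3 (0.66 log units; beyond the scatter), which is modest, and a 12-fold higher number from compound 2 to compound 3 (1.09 log units; beyond the scatter), which is large. A third, a 2.6-fold lower number from compound 1 to compound 2 (0.42 log units; beyond the scatter), is modest and lies within the side chain at that carbon. Among the compounds with values here, none of them involves 2H-tetrazol-5-yl, so they show only that changes here can move the number. Compound 4 lacks the aminomethyl and (methylamino)methyl groups of the two lower compounds, so no drop of that size is expected. The expected step is a 1.5-fold higher number from compound 3 to compound 4 (0.19 log units; within the scatter), which would not clearly exceed the scatter. For compound 4 the estimated value is 28000 nM, with an expected range from 9000 nM to 85000 nM.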

Compound 4, half-maximal cytotoxic concentration: 2000 nM
The estimate for compound 4 lay 14-fold (1.15 log units) above the measured number; measured number outside the range, below it.
By their numbers in this assay, from the lowest: compounds 2, 4 and 1 (each within the scatter of the next, the first and the last beyond it); then compound 3.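

In this assay the change from bromo to 2H-tetrazol-5-yl gives a 9.1-fold lower number from compound 3 to compound 4 (0.96 log units; beyond the scatter) and so shows that a low number at this aromatic carbon does not require an aminomethyl or (methylamino)methyl group. Compound 4 cannot be told apart from either of the two amine compounds, with a 1.4-fold higher number from compound 2 to compound 4 (0.13 log units; within the scatter) and a 2.0-fold lower number from compound 1 to compound 4 (0.29 log units; within the scatter) as the printed steps. Of the four groups seen at this carbon, only bromo stands clear of the others, although compounds 1 and 2 also differ from each other beyond the scatter.

Going by these compounds, whether bromo is the exception here remains open, since a chloro group, a carboxylic acid or plain hydrogen at this carbon could fall on either side of that gap. No measurement at hand offers a reason for the drop.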